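Three Measured Amides and a Sulfonamide Awaiting Its Number

The source may report more compounds than this note shows. Statements on the series, on what has been measured and on what is new or still open speak of the compounds shown alone.

Three compounds have so far been measured in a functional assay on SiHa cells (Homo sapiens) for cytotoxicity, read by MTT assay, with a stated time of 48 h; on this read-out lower numbers stand for stronger inhibition and higher numbers for weaker inhibition:

Compound 1 `CCCCCCCCCCCCNC(=O)[C@@H](NC(=O)c1ccco1)[C@@H](C)O` gives 64300 nM.
Compound 2 `CCCCCCCCCCCCCCNC(=O)[C@@H](NC(=O)c1ccco1)[C@@H](C)O` gives 127000 nM.
Compound 3 `CCCCCCCCCCCCCCCCCCNC(=O)[C@@H](NC(=O)c1ccco1)[C@@H](C)O` gives 13400 nM.

Compound 3 stands lowest of the three. The step of a 4.8-fold lower number from compound 1 to compound 3 (0.68 log units; beyond the scatter) and the step of a 9.5-fold lower number from compound 2 to compound 3 (0.98 log units; beyond the scatter) both lie beyond the scatter, while the step of a 2.0-fold higher number from compound 1 to compound 2 (0.30 log units; within the scatter) does not, so compounds 1 and 2 cannot be placed in any order against each other. All three measured steps concern only the length of the saturated chain; the group on the amine nitrogen is the same in each.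

Compound 4 `CCCCCCCCCCCCCCCCCCNC(=O)[C@@H](NS(=O)(=O)c1ccc(C)cc1)[C@@H](C)O` differs from compound 3 in exactly that place: (4-methylphenyl)sulfonyl in place of (furan-2-yl)carbonyl on an amine nitrogen. For the measured compounds named here, none of the measured steps bears on this change, since none of them alters the group on the amine nitrogen. There is therefore no measured ground for expecting a step in this assay in either direction, and the honest expectation is a step of about no change at the digits printed from compound 3 to compound 4 (within the scatter), that is, none beyond the scatter, with wide uncertainty. Compound 4 is estimated at 13400 nM, within a range from 2500 nM to 70000 nM.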

Compound 4, half-maximal inhibitory concentration: 29800 nM
Estimate against measurement, compound 4: 2.2-fold (0.35 log units) below; the range from low to high includes it.
By their numbers in this assay, from the lowest: compound 3; then compound 4; then compounds 1 and 2 (each within the scatter of the next).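

On the amine nitrogen, with the chain of compound 3 held fixed, putting (4-methylphenyl)sulfonyl in place of (furan-2-yl)carbonyl in this assay gives a 2.2-fold higher number from compound 3 to compound 4 (0.35 log units; beyond the scatter), a modest step that lies beyond the scatter. For the compounds shown here, this is the first reading at this position, which the chain steps left untouched, and it shows that the position responds to a change of group, with (furan-2-yl)carbonyl giving the lower number of this pair. Nothing in the available evidence accounts for the direction or size of this step. The exchange alters the ring and the link to the nitrogen together, so the compounds shown cannot say how much of the step belongs to either, and a benzoyl group or a methanesulfonyl group on the same nitrogen would separate the two. Also open, on these data alone, are how a free amine would read at this position and whether (4-methylphenyl)sulfonyl would give a similar step on the shorter chains of compound 1 and compound 2.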